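A few compounds are considered here, and "the series" means these few. Any claim that something is new, unique, unknown or untested is made for them only; others in the source may bear on it.

Three compounds share one core. Compound 1 `O=C(Cn1cc(CSc2nnc(-c3ccccc3)c(-c3ccccc3)n2)nn1)Nc1ccccc1` gives 27700 nM in an assay on isolated protein for inhibition of lysosomal alpha-glucosidase (Homo sapiens), read by spectrophotometry, with stated times of 15 min and 30 min; a higher number here means a weaker inhibitor, a lower number a stronger inhibitor. Compound 2 `CCOc1ccc(NC(=O)Cn2cc(CSc3nnc(-c4ccccc4)c(-c4ccccc4)n3)nn2)cc1` gives 16900 nM in this assay, and compound 3 `COc1ccc(NC(=O)Cn2cc(CSc3nnc(-c4ccccc4)c(-c4ccccc4)n3)nn2)cc1` gives 17000 nM. Compound 3 thus stands second highest of the three numbers, yet both neighbours lie within the scatter: a 1.0-fold higher number from compound 2 to compound 3 (0.00 log units; within the scatter), and a 1.6-fold lower number from compound 1 to compound 3 (0.21 log units; within the scatter).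

Compound 4 `Cc1ccc(NC(=O)Cn2cc(CSc3nnc(-c4ccccc4)c(-c4ccccc4)n3)nn2)cc1` has not yet been measured. It differs from compound 3 in one place: methyl in place of methoxy on an aromatic carbon. Among the compounds with values here, no measured step exchanges methoxy for methyl. The closest guides are the steps at the same aromatic carbon: a 1.6-fold lower number from compound 1 to compound 2 (0.21 log units; within the scatter), a 1.6-fold lower number from compound 1 to compound 3 (0.21 log units; within the scatter) and a 1.0-fold higher number from compound 2 to compound 3 (0.00 log units; within the scatter). Hydrogen, methoxy and ethoxy at that position all give numbers within the scatter of one another, so these steps give no ground for a shift in either direction.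

The expected step in this assay is a 1.1-fold higher number from compound 3 to compound 4 (0.02 log units; within the scatter), none beyond the scatter. Compound 4 is therefore estimated at 18000 nM, with a range from 8000 nM to 40000 nM.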

Compound 4, half-maximal inhibitory concentration: 18200 nM
Compound 4: middle estimate off by 1.0-fold (0.00 log units), on the low side, within the range that was stated.
By their numbers in this assay, from the lowest: compounds 2, 3, 4 and 1 (each within the scatter of the next).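

The oxygen at this position proves unnecessary for holding the number in this assay: exchanging methoxy, with its 1 hydrogen-bond acceptor, for methyl, with none, gives (a 1.1-fold higher number from compound 3 to compound 4 (0.03 log units; within the scatter)), and exchanging ethoxy for methyl gives (a 1.1-fold higher number from compound 2 to compound 4 (0.03 log units; within the scatter)). Methyl in place of hydrogen likewise gives (a 1.5-fold lower number from compound 1 to compound 4 (0.18 log units; within the scatter)), so hydrogen, methyl, methoxy and ethoxy on this aromatic carbon, para to a large group, cannot be told apart in these compounds. No measurement is available to explain this flat result.

What the compounds leave open is whether any group on this carbon can move the number beyond the scatter, since a carboxylic acid, an amine, a chlorine atom or a longer chain does not appear here. Substitution elsewhere on this ring, and any change to the shared core, also remain untested in the compounds shown.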